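Swapping the Aryl Ketone Partner in Compound 1

This account rests on a few compounds, and the source may have more. Where it says the series, first, only, none or still open, it means among the compounds named here.

Among the compounds with values here, compound 1 `COc1cc(-c2cc(/C=C/C(=O)c3ccc(N)cc3)[nH]n2)cc(OC)c1OC` is one of three compounds measured in a functional assay on OVCAR-4 cells (Homo sapiens) for cytotoxicity, read by sulforhodamine B assay, with a stated time of 48 h, tested at 1 uM (on this read-out higher numbers stand for a weaker effect at the one concentration tested and lower numbers for a stronger effect), where compound 1 gives 62%. Among these three numbers it stands second highest. Its nearest neighbour is compound 3 `COc1ccc(-c2cc(/C=C/C(=O)c3cc(OC)c(OC)c(OC)c3)[nH]n2)cc1OC`, which gives 66% in this assay, a difference within the scatter, so the two cannot be ordered. Furthest away is compound 2 `COc1ccc(-c2cc(/C=C/C(=O)c3ccc(OC)c(OC)c3)[nH]n2)cc1`, which gives 39% in this assay, a gap beyond the scatter, so compound 2 shows the stronger effect of the pair.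

Compound 4 `COc1ccc(C(=O)/C=C/c2cc(-c3cc(OC)c(OC)c(OC)c3)n[nH]2)cc1OC` has not yet been measured. It differs from compound 1 in one place: 3,4-dimethoxyphenyl in place of 4-aminophenyl on a carbonyl carbon. Compound 2 also carries a 3,4-dimethoxyphenyl on a carbonyl carbon, and its value in this assay is the lowest of the three, which gives some footing for an expectation.

Within the data shown here, no step between measured compounds that differ in a single place is available, so the size of this change must be estimated. The account expects the step of a number 12 percentage points lower from compound 1 to compound 4 (beyond the scatter) to be a decrease of moderate size, probably beyond the scatter, since compound 2 sits at 39%. For compound 4 the estimate in this assay is 50%, with a range from 32% to 68%.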

Compound 4, a percentage reported as activity, at one concentration (the size of the read-out at that concentration, not a potency): 70%
Compound 4: the middle estimate sits 20 percentage points below what was measured; measured number above the stated range.
By their numbers in this assay, from the lowest: compound 2; then compounds 1, 3 and 4 (each within the scatter of the next).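

In this assay, within the data shown here, the exchange of 4-aminophenyl for 3,4-dimethoxyphenyl on a carbonyl carbon gives a number 8 percentage points higher from compound 1 to compound 4 (within the scatter) and is the first single-place step available here: with the rest of compound 1 held fixed, a group with more heavy atoms and no hydrogen-bond donor leaves the read-out within the scatter. Compound 2 carries the same 3,4-dimethoxyphenyl on a carbonyl carbon and gives 39% in this assay, whereas compound 4 gives 70% there, so the value of compound 2 does not follow from that group alone, and the two compounds differ elsewhere on the core. No measurement at hand accounts for how little this exchange changes the read-out.

Left open is whether a 4-hydroxyphenyl, a plain phenyl or a 4-carboxyphenyl on the same carbonyl carbon would also stay within the scatter of compound 1. Equally open, going by these compounds, is whether the same exchange would give a step of like size on the core of compound 2, or at any concentration other than the one tested.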